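Halogen-free aryl on the ring nitrogen

The source may hold more compounds than are shown below. What is called first, only, known or untested is meant among the compounds shown, and "the series" means these compounds.

Among the compounds with values here, compound 2 `O=C1COc2ccc(-c3nn(-c4cc(Cl)cc(Cl)c4)cc3-c3ccccc3)cc2N1` gives 70.2% in a functional assay on A549 cells (Homo sapiens) for cytotoxicity, read by colorimetric assay and MTT assay, with a stated time of 3 days, tested at 20 uM (on this read-out lower numbers stand for a stronger effect and higher numbers for a weaker effect at the one concentration tested), the highest of the two numbers so far; compound 1 `O=C1COc2ccc(-c3nn(-c4ccc(F)cc4)cc3-c3ccccc3)cc2N1` gives 56.4%. Within the data shown here, the one step that bears on the next change is a number 13.8 percentage points higher from compound 1 to compound 2 (beyond the scatter). Compound 3 `O=C1COc2ccc(-c3nn(-c4ccccc4)cc3-c3ccccc3)cc2N1` carries the change (phenyl in place of 3,5-dichlorophenyl on an aromatic nitrogen). Since phenyl shares the unsubstituted pattern of neither measured aryl group, the estimate rests loosely on a number 13.8 percentage points higher from compound 1 to compound 2 (beyond the scatter) and places compound 3 part-way back toward compound 1, so that an estimated step of a number 10.2 percentage points lower from compound 2 to compound 3 (beyond the scatter) is expected. Compound 3 is therefore estimated at 60%, within 46% to 74%.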

Compound 3, a percentage reported as activity, at one concentration (the size of the read-out at that concentration, not a potency): 59.7%
Estimate against measurement, compound 3: 0.3 percentage points above; the measured number falls inside the stated range.
By their numbers in this assay, from the lowest: compounds 1 and 3 (each within the scatter of the next); then compound 2.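

Within this assay, the 3,5-dichlorophenyl group on the aromatic nitrogen now stands apart from phenyl as well as from 4-fluorophenyl, on the weaker side (a number 10.5 percentage points lower from compound 2 to compound 3 (beyond the scatter)). Hydrogen in place of fluoro gives no readable difference (a number 3.3 percentage points higher from compound 1 to compound 3 (within the scatter)), so compound 1 and compound 3 sit level at this position. No measured evidence explains the gap.
Going by these compounds, whether one chlorine alone would give the same step remains open. So does the outcome with an amine or a carboxylic acid on this phenyl ring.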